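A few compounds are considered here, and "the series" means these few. Any claim that something is new, unique, unknown or untested is made for them only; others in the source may bear on it.

Compound 1 `O=C(c1ccccc1Cl)N1N=C(c2cc3ccccc3oc2=O)CC1c1ccccc1`: 5440 nM in a functional assay on HepG2 cells (Homo sapiens) for cytotoxicity, read by MTT assay, with a stated time of 48 h; on this read-out higher numbers stand for weaker inhibition and lower numbers for stronger inhibition
Compound 2 `O=C(CNC1CCCCC1)N1N=C(c2cc3ccccc3oc2=O)CC1c1ccccc1`: 34400 nM in this assay

Compound 2 gives the highest number of the two, with compound 1 the nearer neighbour by the step of a 6.3-fold higher number from compound 1 to compound 2 (0.80 log units; beyond the scatter). Compound 3 `NC(=O)C1CCN(CC(=O)N2N=C(c3cc4ccccc4oc3=O)CC2c2ccccc2)CC1` differs from compound 2 by 4-carbamoylpiperidin-1-yl in place of cyclohexylamino on a saturated chain carbon bound to a carbonyl carbon. For the measured compounds named here, only one measured step touches this position, and it swaps a different kind of group, so it bears on the change only loosely. The expected step of a 1.1-fold lower number from compound 2 to compound 3 (0.06 log units; within the scatter) is therefore small and within the scatter. Compound 3 is estimated at 30000 nM, with a range from 10000 nM to 90000 nM.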

Compound 3, half-maximal inhibitory concentration: 19300 nM
Compound 3: middle estimate off by 1.6-fold (0.19 log units), on the high side, and the stated range covers the measured number.
By their numbers in this assay, from the lowest: compound 1; then compounds 3 and 2 (each within the scatter of the next).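

In this assay, the step of a 1.8-fold lower number from compound 2 to compound 3 (0.25 log units; within the scatter) shows that this larger group, with its extra nitrogen and carbamoyl, cannot be told apart from cyclohexylamino at this place. Replacing 2-chlorophenyl with (4-carbamoylpiperidin-1-yl)methyl still gives a 3.5-fold higher number from compound 1 to compound 3 (0.55 log units; beyond the scatter) and so a second amine-bearing chain also stands clearly apart from the 2-chlorophenyl compound. Nothing available explains either step. Going by these compounds, whether a carboxylic acid or a longer chain at this place would shift the number remains open, as does the result for plain piperidin-1-yl without the carbamoyl group.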